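Swapping the Aryl Group on Compound 3's Five-Membered Ring

The compounds below may be only part of what the source reports. "The series", "measured", "known", "first", "only" and "open" are said of these compounds alone.

Measured compounds:
Compound 1 `CCCCCCc1cn(C(c2ccccc2)c2cc3cc(Br)ccc3nc2OC)nn1` gives 6.08%
Compound 2 `COc1nc2ccc(Br)cc2cc1C(c1ccccc1)n1cc(CO)nn1` gives 15%
Compound 3 `COc1nc2ccc(Br)cc2cc1C(c1ccccc1)n1cc(-c2ccccc2C(F)(F)F)nn1` gives 11.4%

In an ADME assay on PANC-1 cells (Homo sapiens) for cytotoxicity, read by sulforhodamine B assay, with a stated time of 48 h, tested at 10 uM (a lower number here means less inhibition, a higher number more inhibition at the concentration tested (going by the name of the read-out)), compound 3 stands second highest of the three numbers. Its nearest neighbour is compound 2, with a step of a number 3.6 percentage points lower from compound 2 to compound 3 (within the scatter), and its furthest is compound 1, with a step of a number 5.3 percentage points higher from compound 1 to compound 3 (within the scatter); both lie within the scatter. Compound 4 `COc1nc2ccc(Br)cc2cc1C(c1ccccc1)n1cc(-c2cccc(F)c2)nn1` differs from compound 3 in one place: 3-fluorophenyl in place of 2-(trifluoromethyl)phenyl on an aromatic carbon. The two steps that bear on this change, the ones into compound 3 from compound 1 and from compound 2, alter the group on the same aromatic carbon and both stayed within the scatter. Compound 4 is therefore expected to show a step of a number 0.4 percentage points lower from compound 3 to compound 4 (within the scatter), none beyond the scatter. The estimate for compound 4 is 11%, ranging from 3% to 20%.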

Compound 4, a percentage reported as inhibition, at one concentration (the size of the read-out at that concentration, not a potency): 15.5%
Compound 4: the middle estimate sits 4.5 percentage points below what was measured; the measured number falls inside the stated range.
By their numbers in this assay, from the lowest: compounds 1, 3, 2 and 4 (each within the scatter of the next).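

In this assay, a fluorinated aryl group with a different substitution, 3-fluorophenyl, still leaves every step within the scatter: a number 4.1 percentage points higher from compound 3 to compound 4 (within the scatter), a number 0.5 percentage points higher from compound 2 to compound 4 (within the scatter) and a number 9.4 percentage points higher from compound 1 to compound 4 (within the scatter). The widest step seen so far at this aromatic carbon of the five-membered ring, the one from hexyl, also stays within the scatter, so the four groups shown there cannot be ranked. Nothing available accounts for these steps.

From the compounds shown here alone, whether an amine or a carboxylic acid on this carbon would give a step beyond the scatter remains open.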